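The source may report more compounds than this note shows. Statements on the series, on what has been measured and on what is new or still open speak of the compounds shown alone.

Three thioureas built on one shared core have been measured in a functional assay on NCI-H460 cells (Homo sapiens) for inhibition, read by CCK-8 assay, with a stated time of 48 h; on this read-out lower numbers stand for stronger inhibition and higher numbers for weaker inhibition. Compound 1 `Cc1ccc(NC(=S)NC(=O)c2cn(-c3ccccc3)nc2-c2ccc(F)cc2)cc1` gives 2980 nM. Compound 2 `Cc1ccc(NC(=S)NC(=O)c2cn(-c3ccccc3)nc2-c2ccc(C)cc2)cc1` gives 3760 nM, and compound 3 `Cc1ccc(NC(=S)NC(=O)c2cn(-c3ccccc3)nc2-c2ccccc2)cc1` gives 3960 nM. On these numbers compound 2 sits between the other two, and both gaps are within the scatter: a 1.1-fold higher number from compound 2 to compound 3 (0.02 log units; within the scatter), while a 1.3-fold higher number from compound 1 to compound 2 (0.10 log units; within the scatter), and a 1.3-fold higher number from compound 1 to compound 3 (0.12 log units; within the scatter). All three measured steps concern the aryl ring carried on the shared core, and none of them moves the read-out beyond the scatter.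

Compound 4 `Cc1ccc(-c2nn(-c3ccccc3)cc2C(=O)NC(=S)Nc2ccc(F)cc2)cc1` differs from compound 2 at the other end of the molecule: fluoro in place of methyl on an aromatic carbon. Among the measured compounds shown here, no measured step touches this ring, so the three known steps bear on it only by analogy: exchanging fluoro, methyl and hydrogen on the other aryl ring left the numbers essentially where they were. On that basis compound 4 is expected to show no step beyond the scatter in this assay, a 1.1-fold lower number from compound 2 to compound 4 (0.03 log units; within the scatter). The estimate for compound 4 is therefore 3500 nM, with a range from 1800 nM to 7000 nM.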

Compound 4, half-maximal inhibitory concentration: 3980 nM
Compound 4: middle estimate off by 1.1-fold (0.06 log units), on the low side, and the stated range covers the measured number.
By their numbers in this assay, from the lowest: compounds 1, 2, 3 and 4 (each within the scatter of the next).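

In this assay, the exchange of methyl for fluoro on the ring at the other end of the molecule, 4-methylphenyl to 4-fluorophenyl, gives a 1.1-fold higher number from compound 2 to compound 4 (0.02 log units; within the scatter). Among the compounds shown here, this is the first measured step at this ring, and it shows that this exchange, like the fluoro, methyl and hydrogen exchanges on the aryl ring of the shared core, does not carry the read-out beyond the scatter, so that across the four compounds neither end has yet produced a step that can be told from the scatter. No evidence is available on what lies behind this result.

One pair of groups at this place says little about the place as a whole, and the compounds shown leave open whether hydrogen, a nitrile, an amine or a carboxylic acid there would give a step beyond the scatter. They also leave open how the read-out would respond to a group such as a methoxy or a carboxylic acid on the phenyl ring of the shared core, which carries no substituent in any of the four compounds.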